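Methyl for Methoxy on a Shared Carbamate Core

The source may report more compounds than this note shows. Statements on the series, on what has been measured and on what is new or still open speak of the compounds shown alone.

Of the compounds shown here, two sharing one core have been measured for growth inhibition. Compound 1 `COc1ccc(OC(=O)Nc2ccc([Se]C#N)cc2)cc1` gives 23700 nM in a functional assay on HTB-54 cells (Homo sapiens) for cytotoxicity, read by MTT assay, with a stated time of 72 h; on this read-out higher numbers stand for weaker inhibition of growth and lower numbers for stronger inhibition of growth. Compound 2 `C=CCOC(=O)Nc1ccc([Se]C#N)cc1` gives 27000 nM in this assay. Compound 1 has the lower of the two numbers, but compound 2 lies within the scatter of it, so the two cannot be told apart on this read-out.

Compound 3 `Cc1ccc(OC(=O)Nc2ccc([Se]C#N)cc2)cc1` differs from compound 1 in one place: methyl in place of methoxy on an aromatic carbon. For the measured compounds named here, no measured pair shows the effect of this particular change, so the size of the step cannot be read from a neighbour. The two measured compounds differ from each other on the oxygen side of the shared core, and their values sit within the scatter of each other, which gives no sign that changes of this kind move the read-out much. Compound 3 is therefore expected to stay close, with an expected step of a 1.1-fold higher number from compound 1 to compound 3 (0.02 log units; within the scatter), no larger than the scatter in either direction. Compound 3 is estimated at 25000 nM, with a range from 12000 nM to 50000 nM.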

Compound 3, concentration for 50% growth inhibition: 17300 nM
For compound 3 the middle estimate is 1.4-fold (0.16 log units) above the measured one; the range from low to high includes it.
By their numbers in this assay, from the lowest: compounds 3, 1 and 2 (each within the scatter of the next).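

In this assay, for the compounds shown here, methyl in place of methoxy on an aromatic carbon, para to a large group, gives a 1.4-fold lower number from compound 1 to compound 3 (0.14 log units; within the scatter) and this is the first direct reading of a change at this position. The two earlier compounds differ on the oxygen side of the shared core, whereas compound 1 and compound 3 differ only in this one group, so this pair isolates the position. The methoxy group counts one hydrogen-bond acceptor and the methyl none, yet on this read-out compound 1 and compound 3 cannot be told apart, and no available data bear on the reason for this result.

The compounds shown leave open whether any group at this position can move the read-out beyond the scatter, since this single step rests on methoxy and methyl alone. From the compounds shown here alone, how an amine, a carboxylic acid or a longer chain such as butoxy would behave on this aromatic carbon remains unknown, as does whether the near-equal values of this pair would hold for groups of a different kind.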